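The compounds below may be only part of what the source reports. "The series", "measured", "known", "first", "only" and "open" are said of these compounds alone.

Compound 2 `O=C1O[C@H]([C@@H](O)Cn2cc(-c3cccc(O)c3)nn2)C(OCc2ccccc2)=C1OCc1ccccc1` is the point of departure. In an ADME assay on HFF cells (Homo sapiens) for cytotoxicity, read by MTT assay, with a stated time of 72 h (on this read-out lower numbers stand for stronger inhibition and higher numbers for weaker inhibition), compound 2 gives 39000 nM, the highest of the two numbers given, with compound 3 nearest. Compound 3 `CCCCc1cn(C[C@H](O)[C@H]2OC(=O)C(OCc3ccccc3)=C2OCc2ccccc2)nn1` gives 26300 nM in this assay, and the step of a 1.5-fold lower number from compound 2 to compound 3 (0.17 log units; within the scatter) is within the scatter. Compound 1 `O=C1O/C(=C\Cn2cc(-c3ccc(Br)cc3)nn2)C(OCc2ccccc2)=C1OCc1ccccc1` gives > 100000 nM in this assay, which is a limit of the assay and not a number; the limit of > 100000 nM in this assay, at which 1 of the 3 values shown sits, describes this limit.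

Compound 4 `C[Si](C)(C)c1cn(C[C@H](O)[C@H]2OC(=O)C(OCc3ccccc3)=C2OCc2ccccc2)nn1` is not yet measured. Relative to compound 2 the change is a group of 4 heavy atoms (3 carbon, 1 silicon; no ring) in place of a group of 7 heavy atoms (6 carbon, 1 oxygen; one six-membered aromatic ring of carbon only), on an aromatic carbon. For the measured compounds named here, the one measured step that bears on it is the step from compound 2 to compound 3, which also removed the 3-hydroxyphenyl from that same aromatic carbon and replaced it with a group without a ring, and it stayed within the scatter. On that basis no step beyond the scatter is expected for compound 4, and the expected step of a 1.3-fold lower number from compound 2 to compound 4 (0.11 log units; within the scatter) reflects this. Compound 4 is therefore estimated to give 30000 nM in this assay, with a range from 10000 nM to 100000 nM.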

Compound 4, half-maximal inhibitory concentration: 20000 nM
Compound 4: the middle estimate sits 1.5-fold (0.18 log units) above what was measured; measured number inside the range.
By their numbers in this assay, from the lowest: compounds 4, 3 and 2 (each within the scatter of the next). At a limit, above all of these: compound 1.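

In this assay, the aromatic carbon of the five-membered ring has now carried three different groups, and the new replacement of 3-hydroxyphenyl gives a 2.0-fold lower number from compound 2 to compound 4 (0.29 log units; within the scatter). The group of 4 heavy atoms (3 carbon, 1 silicon) also matches butyl in heavy-atom count while bringing silicon to this position, and that exchange gives a 1.3-fold lower number from compound 3 to compound 4 (0.12 log units; within the scatter), so this read-out does not separate the aryl group, the all-carbon chain and the silicon-bearing group. Nothing measured here gives a reason for these steps.

On these data alone, it remains open whether an amine or a carboxylic acid on this aromatic carbon would give a step beyond the scatter. The same question stands for a chain longer than butyl.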